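This account rests on a few compounds, and the source may have more. Where it says the series, first, only, none or still open, it means among the compounds named here.

Compound 1, with structure `Nc1ccc(S(=O)(=O)N2CCN(c3ncc(C(O)(C(F)(F)F)C(F)(F)F)cc3-c3ccccc3O)CC2)cn1`, is the compound at the top of this small set: in an ADME assay (liver) for metabolic stability, with Liver microsome (Rattus norvegicus) as the target, using microsomes and NADPH, with a stated time of 30 min, tested at 1 uM (a lower number here means slower removal, a higher number faster removal of the compound), compound 1 gives 125 mL.min-1.g-1, the highest of the three numbers measured. Its two neighbours differ from it only in the aromatic group that sits on the shared core. Compound 2, `Nc1ccc(S(=O)(=O)N2CCN(c3ncc(C(O)(C(F)(F)F)C(F)(F)F)cc3-c3ccncc3)CC2)cn1`, carries pyridin-4-yl in place of 2-hydroxyphenyl and gives 31 mL.min-1.g-1; compound 3, `Nc1ccc(S(=O)(=O)N2CCN(c3ncc(C(O)(C(F)(F)F)C(F)(F)F)cc3-c3cccnc3)CC2)cn1`, carries pyridin-3-yl there and gives 20 mL.min-1.g-1. The corresponding steps are a 4.0-fold lower number from compound 1 to compound 2 (0.61 log units; beyond the scatter) and a 6.3-fold lower number from compound 1 to compound 3 (0.80 log units; beyond the scatter), both beyond the scatter, whereas the step of a 1.6-fold lower number from compound 2 to compound 3 (0.19 log units; within the scatter) lies within it.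

Compound 4, `Nc1ccc(S(=O)(=O)N2CCN(c3ncc(C(O)(C(F)(F)F)C(F)(F)F)cc3-c3ccc4[nH]ncc4c3)CC2)cn1`, again alters the same position, as stated by 1H-indazol-5-yl in place of 2-hydroxyphenyl on an aromatic carbon. Both measured steps from compound 1 bear on this change, since each removes the 2-hydroxyphenyl group and each lowers the number by a modest amount. The group that enters here is not a pyridyl, so the size of the effect is uncertain, but the same direction is expected: a lower number than for compound 1, most likely of a modest size, though possibly not beyond the scatter. Compound 4 is therefore expected to give an estimated 50 mL.min-1.g-1, with a range from 20 mL.min-1.g-1 to 120 mL.min-1.g-1, which corresponds to an expected step of a 2.5-fold lower number from compound 1 to compound 4 (0.40 log units; beyond the scatter).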

Compound 4, intrinsic clearance in microsomes: 88 mL.min-1.g-1
Compound 4: middle estimate off by 1.8-fold (0.25 log units), on the low side; the measured number falls inside the stated range.
By their numbers in this assay, from the lowest: compounds 3 and 2 (each within the scatter of the next); then compounds 4 and 1 (each within the scatter of the next).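

In this assay, the loss of the 2-hydroxyphenyl group does not by itself bring the number down: with 1H-indazol-5-yl at this position the result is a 1.4-fold lower number from compound 1 to compound 4 (0.15 log units; within the scatter). The two earlier steps from compound 1 therefore do not hold for every group that takes the place of 2-hydroxyphenyl. Going by these compounds alone, the lower numbers so far belong only to the two pyridyl groups, since the 1H-indazol-5-yl group stands apart from them, with a 4.4-fold higher number from compound 3 to compound 4 (0.64 log units; beyond the scatter) and a 2.8-fold higher number from compound 2 to compound 4 (0.45 log units; beyond the scatter), which shows that the choice among aromatic groups at this position can separate compounds even when the group that leaves is the same. No measurement given here accounts for this difference between the groups.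

The compounds shown leave open whether a plain phenyl group, a pyridin-2-yl group, or a phenyl group carrying an amine or a carboxylic acid at this position would side with the two pyridyl compounds or with compound 1 and compound 4. They also leave open whether the gap between the pyridyl groups and the 1H-indazol-5-yl group would persist with a different group elsewhere on the shared core.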